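A few compounds are considered here, and "the series" means these few. Any claim that something is new, unique, unknown or untested is made for them only; others in the source may bear on it.

Working notes on the series. The shared core is carried through all three measured compounds; compound 1 is `CC(C)[C@H](NC(=O)COc1cccc2ccccc12)C(=O)N[C@@H](CC(=O)O)C(=O)CSc1nc(-c2ccccc2)cs1`, compound 2 is `CC(C)[C@H](NC(=O)COc1cccc2ccccc12)C(=O)N[C@@H](CC(=O)O)C(=O)CSc1nncn1C` and compound 3 is `CC(C)[C@H](NC(=O)COc1cccc2ccccc12)C(=O)N[C@@H](CC(=O)O)C(=O)CSc1nc2ccccc2s1`. In a functional assay on Jurkat cells (Homo sapiens) for inhibition (on this read-out higher numbers stand for weaker inhibition and lower numbers for stronger inhibition), compound 1 gives only a limit of the assay, > 200000 nM. In this assay compound 2 likewise gives only a limit, > 200000 nM. In this assay compound 3 also gives only a limit, > 200000 nM. Compound 3 therefore stands nowhere readable on the numbers shown: all three values sit at the same limit (the limit of > 200000 nM in this assay, at which 3 of the 3 values shown sit), and the three steps among the measured compounds, a step that the two limits leave unreadable from compound 1 to compound 2, a step that the two limits leave unreadable from compound 1 to compound 3 and a step that the two limits leave unreadable from compound 2 to compound 3, carry no readable size.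

The step from compound 3 to compound 4 `CC(C)[C@H](NC(=O)COc1cccc2ccccc12)C(=O)N[C@@H](CC(=O)O)C(=O)COc1nccc2ccccc12` makes the change ((isoquinolin-1-yl)oxy in place of (1,3-benzothiazol-2-yl)sulfanyl on a saturated chain carbon bound to a carbonyl carbon). Among the compounds with values here, none of the measured steps bears on this change: all of them alter only the group attached to the sulfur and keep the sulfanyl link, whereas here the sulfur itself leaves and an oxygen enters together with the isoquinolin-1-yl group. No direction or size can be read from the measured steps.

On the data shown, the expectation for compound 4 in this assay is a value near the limit, 150000 nM, within 5000 nM to 200000 nM, meaning an expected step of an at least 1.3-fold lower number from compound 3 to compound 4 (0.12 log units; that floor lies within the scatter), with a real chance that only a limit is again reported.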

Compound 4, half-maximal inhibitory concentration: 106000 nM
The estimate for compound 4 lay 1.4-fold (0.15 log units) above the measured number; the range from low to high includes it.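

In this assay compound 4 is the only compound shown that gives a number rather than a limit, so (isoquinolin-1-yl)oxy on a saturated chain carbon bound to a carbonyl carbon brings this position into the readable range. Read against the three sulfanyl compounds, the change gives an at least 1.8-fold lower number from compound 3 to compound 4 (0.27 log units; that floor lies within the scatter) and an at least 1.8-fold lower number from compound 2 to compound 4 (0.27 log units; that floor lies within the scatter) and also an at least 1.8-fold lower number from compound 1 to compound 4 (0.27 log units; that floor lies within the scatter) as floors only, so the direction is toward a lower number, while the full size of each step stays unknown. The steps among compound 1, compound 2 and compound 3 cannot be read, and these three stay at one limit, which says nothing about their order: the limit of > 200000 nM in this assay, at which 3 of the 4 values shown sit.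

Still open, from the compounds shown here alone, is whether the oxygen or the isoquinolin-1-yl group carries the step, as both enter in a single change; an (isoquinolin-1-yl)sulfanyl group or a (1,3-benzothiazol-2-yl)oxy group on the same carbon would separate the two. Also open, going by these compounds, is how this position responds to other groups on that carbon, such as a phenoxy group or an amine.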